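The source may hold more compounds than are shown below. What is called first, only, known or untested is meant among the compounds shown, and "the series" means these compounds.

Measured in an assay on isolated protein for binding affinity to 5-hydroxytryptamine receptor 1B (Rattus norvegicus); a higher number here means a weaker inhibitor, a lower number a stronger inhibitor: compound 1 `c1ccc2c(c1)CC(CCN1CCN(c3cccc4c3OCCO4)CC1)C2` gives 692 nM; compound 2 `c1ccc2c(c1)CC(CCCN1CCN(c3cccc4c3OCCO4)CC1)C2` gives 1860 nM; compound 3 `Clc1cccc2c1CC2CCN1CCN(c2cccc3c2OCCO3)CC1` gives 708 nM.

Compound 3 differs from compound 1 by a group of 9 heavy atoms (8 carbon, 1 chlorine; one four-membered non-aromatic ring of carbon only, one six-membered aromatic ring of carbon only) in place of a group of 9 heavy atoms (9 carbon; one five-membered non-aromatic ring of carbon only, one six-membered aromatic ring of carbon only), on a saturated chain carbon, two bonds along the chain from an amine nitrogen in a ring. This exchange made a 1.0-fold higher number from compound 1 to compound 3 (0.01 log units; within the scatter). Compound 2 carries a core that differs from that of compound 1 in a way not broken down here, and it gives the highest number of the three in this assay.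

Compound 4 `Clc1cccc2c1CC2CCCN1CCN(c2cccc3c2OCCO3)CC1` differs from compound 2 by a group of 9 heavy atoms (8 carbon, 1 chlorine; one four-membered non-aromatic ring of carbon only, one six-membered aromatic ring of carbon only) in place of a group of 9 heavy atoms (9 carbon; one five-membered non-aromatic ring of carbon only, one six-membered aromatic ring of carbon only), on a saturated chain carbon, three bonds along the chain from an amine nitrogen in a ring. The change is the same kind as that from compound 1 to compound 3, but its place is three bonds along the chain from the amine nitrogen rather than two, so the comparison is not exact. The step from compound 2 to compound 4 is expected to be a 1.0-fold lower number from compound 2 to compound 4 (0.01 log units; within the scatter), near the earlier one, because the earlier exchange gave a 1.0-fold higher number from compound 1 to compound 3 (0.01 log units; within the scatter). Compound 4 is therefore estimated at 1800 nM, expected within 800 nM to 4000 nM.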

Compound 4, inhibition constant: 1100 nM
The estimate for compound 4 lay 1.6-fold (0.21 log units) above the measured number; the measured number falls inside the stated range.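

In this assay, replacing 2,3-dihydro-1H-inden-2-yl with the chlorine-carrying group that has the four-membered ring gives a 1.7-fold lower number from compound 2 to compound 4 (0.23 log units; within the scatter). The change reads the same on the two cores shown: the same change on two cores in this assay, a 1.0-fold higher number (0.01 log units; within the scatter) from compound 1 to compound 3 and a 1.7-fold lower number (0.23 log units; within the scatter) from compound 2 to compound 4, 1.7-fold (0.24 log units) apart, within the scatter of two such steps. Among the compounds shown here, with only two pairs, and both steps within the scatter, this shows that the exchange leaves the number unmoved to within the scatter on these cores, but not that it would do so on any other core or that it improves binding.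

Still open is whether the match holds on a longer chain than those shown. Also open, going by these compounds, is how the number responds when fluorine or a methoxy group stands in place of the chlorine.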